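Compound 2 to compound 4: exchange on the amine nitrogen

The source may report more compounds than this note shows. Statements on the series, on what has been measured and on what is new or still open speak of the compounds shown alone.

Three compounds of this series have numbers in a functional assay on NCI-H1581 cells (Homo sapiens) for inhibition, read by MTT assay, with a stated time of 48 h, tested at 10 uM; on this read-out lower numbers stand for less inhibition and higher numbers for more inhibition at the one concentration tested (going by the name of the read-out). Compound 1 `COc1ccc(OC)c(Nc2cc(NC(=O)Nc3c(Cl)cccc3Cl)ncn2)c1` gives 93.1%, compound 3 `CC(C)(C)c1cccc(Nc2cc(NC(=O)Nc3c(Cl)cccc3Cl)ncn2)c1` gives 64.3%, and compound 2 `COc1cc(NC(=O)Nc2cc(Nc3cccc(C(C)(C)C)c3)ncn2)cc(OC)c1` gives 35.1%, the lowest of the three; its nearest neighbour is compound 3 and its furthest is compound 1, both beyond the scatter.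

Compound 4 `CCc1ccc(Nc2cc(NC(=O)Nc3cc(OC)cc(OC)c3)ncn2)cc1` is not yet measured. It differs from compound 2 in one place: 4-ethylphenyl in place of 3-(tert-butyl)phenyl on a nitrogen on an aromatic ring.

Among the compounds with values here, the one step measured within one change, a number 29.2 percentage points higher from compound 2 to compound 3 (beyond the scatter), concerns the group on the amide-type nitrogen, not the nitrogen changed here, so it does not bear directly on the step to compound 4. Within the data shown here, compound 1 and compound 3 share the group on the amide-type nitrogen and differ on the amine nitrogen; their two values show that the group on this nitrogen can move the read-out by a large amount, but no single step there is available, and neither compound carries 4-ethylphenyl. The expected step is therefore uncertain in direction and modest in size, with a wide range.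

Compound 4 is estimated at 42% in this assay, within 15% to 72%, which means an expected step of a number 6.9 percentage points higher from compound 2 to compound 4 (within the scatter).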

Compound 4, a percentage reported as inhibition, at one concentration (the size of the read-out at that concentration, not a potency): 32.7%
Beside the measured number, compound 4's estimate is 9.3 percentage points above it, and the stated range covers the measured number.
By their numbers in this assay, from the lowest: compounds 4 and 2 (each within the scatter of the next); then compound 3; then compound 1.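

Exchange on a nitrogen on an aromatic ring gives a number 2.4 percentage points lower from compound 2 to compound 4 (within the scatter) in this assay and is the first single change at this nitrogen that can be read with 3,5-dimethoxyphenyl on the amide-type nitrogen. The leaving and entering groups both have one six-membered aromatic ring of carbon only, and 3-(tert-butyl)phenyl and 4-ethylphenyl differ in their alkyl group and heavy-atom count, yet this difference does not separate compound 2 and compound 4 in this read-out. No measurement is available that accounts for this outcome.

A group with an amine or a carboxylic acid on the phenyl ring at this nitrogen remains untested in the compounds shown, so it is open whether any exchange here lifts the read-out while 3,5-dimethoxyphenyl stays on the amide-type nitrogen. As far as these compounds go, it is also open whether 4-ethylphenyl would read the same way with 2,6-dichlorophenyl on the amide-type nitrogen, the group carried by compound 1 and compound 3.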